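A few compounds are considered here, and "the series" means these few. Any claim that something is new, unique, unknown or untested is made for them only; others in the source may bear on it.

Measured in a functional assay on SK-MEL-28 cells (Homo sapiens) for cytotoxicity, read by CCK-8 assay, with a stated time of 24 h; a lower number here means a stronger inhibitor, a higher number a weaker inhibitor:
- Compound 1 `COc1ccccc1Oc1c(N)nc(-c2ccccc2)nc1Cl`: 3140 nM
- Compound 2 `COc1ccccc1Oc1c(N)nc(-c2ccc(Cl)cc2)nc1Cl`: 120 nM
- Compound 3 `COc1ccccc1Oc1c(N)nc(-c2ccccc2)nc1OCCO`: > 80000 nM (a limit, not a number)

Compound 3 has no measured number, only a limit: the limit of > 80000 nM in this assay, at which 1 of the 3 values shown sits. The next compound to test is compound 4 `COc1ccccc1Oc1c(N)nc(-c2cccc(F)c2)nc1OCCO`, in which phenyl becomes 3-fluorophenyl, with fluoro in place of hydrogen on an aromatic carbon.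

Among the compounds with values here, two measured steps bear on this change. The nearest is a 26-fold lower number from compound 1 to compound 2 (1.42 log units; beyond the scatter), a large gain, but it involves chloro rather than fluoro and a different parent. The other is an at least 25-fold higher number from compound 1 to compound 3 (1.40 log units; beyond the scatter), which is also large and shows how far the 2-hydroxyethoxy parent sits from compound 1. Within the data shown here, no fluoro step has been measured, and no step of any kind starts from compound 3.

A move toward a lower number is therefore expected, though a smaller one than the chloro step, and another limit reading is quite possible. The expected change is an at least 1.6-fold lower number from compound 3 to compound 4 (0.20 log units; that floor lies within the scatter). For compound 4 the estimated value is 50000 nM, with an expected range of 10000 nM to 100000 nM.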

Compound 4, half-maximal inhibitory concentration: 3210 nM
Estimate against measurement, compound 4: 16-fold (1.19 log units) above; the measured number lies below the stated range.
By their numbers in this assay, from the lowest: compound 2; then compounds 1 and 4 (each within the scatter of the next). At a limit, above all of these: compound 3.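

In this assay, fluoro in place of hydrogen on the phenyl ring of the 2-hydroxyethoxy parent gives an at least 24-fold lower number from compound 3 to compound 4 (1.39 log units; beyond the scatter), the only step shown that starts from this parent and the only one with fluoro. A single substituent on this ring thus moves the number by a large step on the 2-hydroxyethoxy parent as well as on the chloro parent, where the step is a 26-fold lower number from compound 1 to compound 2 (1.42 log units; beyond the scatter), though the two steps involve different groups. The true size of the new step remains unknown, since compound 3 carries only a limit and not a number: the limit of > 80000 nM in this assay, at which 1 of the 4 values shown sits.

On these data alone, it remains open whether chloro at the same place on the 2-hydroxyethoxy parent would match fluoro, and whether fluoro would give a similar step on the chloro parent. Also open, as far as these compounds go, is how an amine or a carboxylic acid on this ring, or a longer chain in place of 2-hydroxyethoxy, would read.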